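Vinyl to Ethynyl on the Shared Core: Compound 4

The compounds below may be only part of what the source reports. "The series", "measured", "known", "first", "only" and "open" are said of these compounds alone.

Of the compounds shown here, three with the same core have been measured in an assay on Sf9 cells for inhibition of mitogen-activated protein kinase kinase kinase 14 variant S549D (Homo sapiens), with a stated time of 30 min, in the presence of a further agent that is not named here; a lower number here means a stronger inhibitor, a higher number a weaker inhibitor. Compound 1 `C=Cc1cc(C#Cc2ccc3ncn(-c4ccnc(N)n4)c3c2)ccn1` gives 20000 nM in this assay. Compound 2 `C#Cc1cc(C#Cc2ccc3ncn(-c4ccnc(N)n4)c3c2)ccn1` gives 31600 nM, and compound 3 `C=Cc1nccc(C#Cc2ccc3ncn(-c4ccnc(N)n4)c3c2)n1` gives 39800 nM. Compound 3 shows the highest of the three numbers, but both of its gaps are within the scatter: a 2.0-fold higher number from compound 1 to compound 3 (0.30 log units; within the scatter) and a 1.3-fold higher number from compound 2 to compound 3 (0.10 log units; within the scatter). The three compounds are thus indistinguishable in this assay on the present data.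

Compound 4 `C#Cc1nccc(C#Cc2ccc3ncn(-c4ccnc(N)n4)c3c2)n1` is reached from compound 3 by the change (ethynyl in place of vinyl on an aromatic carbon). The same exchange has been seen once before, from compound 1 to compound 2, where it gave a 1.6-fold higher number from compound 1 to compound 2 (0.20 log units; within the scatter). That step sits on the other six-membered ring, the one with one nitrogen, while in compound 4 the exchange sits on the ring with two nitrogen atoms; nothing in the data says whether that matters. Among the compounds with values here, on the single comparable step, no change beyond the scatter is expected in this assay, with at most a slight rise in the number, a 1.3-fold higher number from compound 3 to compound 4 (0.10 log units; within the scatter).

Compound 4 is therefore estimated at 50000 nM in this assay, with a range from 25000 nM to 100000 nM.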

Compound 4, half-maximal inhibitory concentration: 39800 nM
For compound 4 the middle estimate is 1.3-fold (0.10 log units) above the measured one, within the range that was stated.
By their numbers in this assay, from the lowest: compounds 1, 2, 3 and 4 (each within the scatter of the next).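

In this assay, ethynyl in place of vinyl on the aromatic carbon between two ring nitrogen atoms gives no change at the digits printed from compound 3 to compound 4 (within the scatter), so the exchange leaves no readable mark at this position. The same exchange can now be compared on two cores, and the two readings agree within the scatter: the same change on two cores in this assay, a 1.6-fold higher number (0.20 log units; within the scatter) from compound 1 to compound 2 and no change at the digits printed (within the scatter) from compound 3 to compound 4, 1.6-fold (0.20 log units) apart, within the scatter of two such steps. With ethynyl held in place, exchanging the whole terminal ring group gives a 1.3-fold higher number from compound 2 to compound 4 (0.10 log units; within the scatter), and the step that changes both that ring group and its substituent gives a 2.0-fold higher number from compound 1 to compound 4 (0.30 log units; within the scatter), so the ring with two nitrogen atoms brings no difference beyond the scatter either.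

All four compounds carry only vinyl or ethynyl on the terminal ring, so the data show how little separates these two groups but not how far this position can move the number in this assay. As far as these compounds go, whether an amine, a carboxylic acid or a longer chain on the aromatic carbon between the two ring nitrogen atoms would shift the number beyond the scatter remains open.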